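Acetate to Alcohol on Two Cytotoxic Scaffolds

The compounds below may be only part of what the source reports. "The series", "measured", "known", "first", "only" and "open" are said of these compounds alone.

Compound 1 `COc1ccc(C2=C(c3cc(OC)c(OC)c(OC)c3)C(=O)C(OC(C)=O)C2)cc1F` and compound 2 `COc1ccc(C2=C(c3cc(OC)c(OC)c(OC)c3)C(=O)C(O)C2)cc1F` share one core and differ by hydrogen in place of acetyl on an oxygen on a saturated carbon. In an ADME assay on HT-29 cells (Homo sapiens) for cytotoxicity, read by MTT assay, with a stated time of 72 h (on this read-out lower numbers stand for stronger inhibition and higher numbers for weaker inhibition), compound 1 reaches only a limit of the assay, < 1 ug/mL. Compound 2 likewise gives only a limit, < 1 ug/mL. The step that the two limits leave unreadable from compound 1 to compound 2 cannot be read, since both values sit at the limit of < 1 ug/mL in this assay, at which 2 of the 3 values shown sit.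

Compound 3 `CC(=O)OC1C/C(=N/O)C(c2ccccc2)=C1c1ccccc1` carries a different core; the difference between the two cores is not broken down here. In this assay compound 3 gives only a limit, > 100 ug/mL, the point named by the limit of > 100 ug/mL in this assay, at which 1 of the 3 values shown sits. Compound 4 `O/N=C1/CC(O)C(c2ccccc2)=C1c1ccccc1`, not yet measured, differs from compound 3 by hydrogen in place of acetyl on an oxygen on a saturated carbon, the same change as that between compound 1 and compound 2, made at the same place.

Because a step that the two limits leave unreadable from compound 1 to compound 2 lies between two limits, it gives no size to carry across. The expectation therefore rests on compound 3, whose own value is only a limit, > 100 ug/mL. On this footing the step that the limit leaves unreadable from compound 3 to compound 4 is expected to be small. Compound 4 is estimated at 120 ug/mL in this assay, quite possibly again reported only as a limit.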

Compound 4, half-maximal inhibitory concentration: > 100 ug/mL
Compound 4: no number, only a limit; the forecaster's own chance of this, stated with the estimate: 75%; the middle value lies beyond the limit too.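

In this assay compound 4 gives only a limit of the assay, > 100 ug/mL. No step can be read between compound 3 and compound 4, because both rest on the same limit: the limit of > 100 ug/mL in this assay, at which 2 of the 4 values shown sit.

The compounds shown leave open how far the change from acetoxy to hydroxy moves the value on either core.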